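Methyl branch on the acrylamide chain across two cores

This account rests on a few compounds, and the source may have more. Where it says the series, first, only, none or still open, it means among the compounds named here.

Measured so far:
compound 1, `CC/C=C\C(=O)Nc1cc(Nc2ncc(C#N)c(-c3cn(C)c4ccccc34)n2)c(OC)cc1N(C)CCN(C)C`, 162 nM
compound 2, `COc1cc(N(C)CCN(C)C)c(NC(=O)/C=C\C(C)C)cc1Nc1ncc(C#N)c(-c2cn(C)c3ccccc23)n1`, 1100 nM
compound 3, `CC/C=C\C(=O)Nc1cc(Nc2nc(C)cc(-c3cn(C)c4ccccc34)n2)c(OC)cc1N(C)CCN(C)C`, 1090 nM

In a functional assay on A549 cells (Homo sapiens) for antiproliferative activity, read by MTT assay, with a stated time of 72 h (on this read-out higher numbers stand for weaker inhibition and lower numbers for stronger inhibition), compound 1 gives 162 nM. Compound 2 carries the change (methyl in place of hydrogen on a saturated chain carbon bound to a double-bonded chain carbon and a saturated chain carbon); the result is a 6.8-fold higher number from compound 1 to compound 2 (0.83 log units; beyond the scatter). Compound 3 has the core of compound 1 replaced by another core, and the difference between the two cores is not broken down here. In this assay compound 3 gives 1090 nM, which sits within the scatter of compound 2.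

Compound 4, `COc1cc(N(C)CCN(C)C)c(NC(=O)/C=C\C(C)C)cc1Nc1nc(C)cc(-c2cn(C)c3ccccc23)n1`, carries the same change on the core of compound 3: methyl in place of hydrogen on a saturated chain carbon bound to a double-bonded chain carbon and a saturated chain carbon. The only reading of this change is the step from compound 1 to compound 2; whether it carries over to the other core is not shown by the measured compounds. Taking that step as the guide, a weakening of similar direction is expected, a 5.0-fold higher number from compound 3 to compound 4 (0.70 log units; beyond the scatter), because a 6.8-fold higher number from compound 1 to compound 2 (0.83 log units; beyond the scatter). For compound 4 the estimated value in this assay is 5500 nM, with an expected range of 1500 nM to 16000 nM.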

Compound 4, half-maximal inhibitory concentration: 1070 nM
Beside the measured number, compound 4's estimate is 5.1-fold (0.71 log units) above it, and the stated range ends above it.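

On the core of compound 3, methyl in place of hydrogen on the saturated chain carbon leaves the number in this assay within the scatter (a 1.0-fold lower number from compound 3 to compound 4 (0.01 log units; within the scatter)). The change therefore does not carry over from one core to the other with the size it had on the core of compound 1, and the two steps differ: the same change on two cores in this assay, a 6.8-fold higher number (0.83 log units; beyond the scatter) from compound 1 to compound 2 and a 1.0-fold lower number (0.01 log units; within the scatter) from compound 3 to compound 4, 6.9-fold (0.84 log units) apart, beyond the scatter of two such steps. Going by these compounds alone, with one pair on each core, this shows only that the step from but-1-en-1-yl to 3-methylbut-1-en-1-yl cannot be transferred between these two cores in this assay; it does not show which part of the core difference accounts for the gap, or why the gap arises.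

On these data alone, it remains open how the same methyl behaves on any further core, and which of the two steps such a core would resemble. Also open, as far as these compounds go, is whether a longer chain or an amine at the end of the chain would differ between these two cores in the same way.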